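Changing the ring on the carbonyl: a fourth analogue

The source may report more compounds than this note shows. Statements on the series, on what has been measured and on what is new or still open speak of the compounds shown alone.

Measured so far:
compound 1, `COc1ccc(/C=C/c2cc(OC)cc(OC)c2/C=C/C(=O)c2ccc(C)cc2)cc1`: 5.3 ug/mL
compound 2, `COc1ccc(/C=C/c2cc(OC)cc(OC)c2/C=C/C(=O)c2cccc(Cl)c2)cc1`: 3.3 ug/mL
compound 3, `COc1ccc(/C=C/c2cc(OC)cc(OC)c2/C=C/C(=O)c2ccc(N)cc2)cc1`: 2.8 ug/mL

All three compounds share one core and differ only in the ring attached to the carbonyl carbon. In a functional assay on B16-F10 cells (Mus musculus) for antiproliferative activity, read by MTT assay, with a stated time of 48 h (a lower number here means a stronger inhibitor, a higher number a weaker inhibitor), compound 1 gives 5.3 ug/mL, compound 2 gives 3.3 ug/mL and compound 3 gives 2.8 ug/mL. Compound 2 sits second highest of the three numbers; its nearest neighbour is compound 3 and its furthest is compound 1, and both gaps are within the usual scatter, so the three compounds cannot be told apart on these numbers.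

Compound 4 is `COc1ccc(/C=C/c2cc(OC)cc(OC)c2/C=C/C(=O)c2ccc(C)c(C)c2)cc1`, and it differs from compound 2 in one place: 3,4-dimethylphenyl in place of 3-chlorophenyl on a carbonyl carbon

Going by the values given here, two measured steps bear on this change, both made at the same carbonyl carbon. The step of a 1.6-fold lower number from compound 1 to compound 2 (0.21 log units; within the scatter) and the step of a 1.2-fold lower number from compound 2 to compound 3 (0.07 log units; within the scatter) were each within the scatter. Compound 4 carries a methyl-bearing ring much like compound 1, which stands closest in structure, and that compound also sits within the scatter of compound 2. Nothing measured here points to a step beyond the scatter in either direction, so compound 4 is expected to give 4.2 ug/mL, between 2 ug/mL and 9 ug/mL, an estimated step of a 1.3-fold higher number from compound 2 to compound 4 (0.10 log units; within the scatter).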

Compound 4, half-maximal inhibitory concentration: 1.4 ug/mL
Compound 4: the middle estimate sits 3.0-fold (0.48 log units) above what was measured; measured number outside the range, below it.
By their numbers in this assay, from the lowest: compounds 4, 3, 2 and 1 (each within the scatter of the next, the first and the last beyond it).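

In this assay, going by these compounds alone, this is the first change on the carbonyl carbon whose size stands beyond the scatter: 3,4-dimethylphenyl in place of 3-chlorophenyl gives a 2.4-fold lower number from compound 2 to compound 4 (0.37 log units; beyond the scatter), and a single methyl in place of hydrogen on the aromatic ring of compound 1 gives a 3.8-fold lower number from compound 1 to compound 4 (0.58 log units; beyond the scatter). The earlier compounds shown here could not be told apart, whereas these two steps show that the number at this position can move with a small change to the ring, even one as small as one added methyl, although the comparison with the 4-aminophenyl ring, a 2.0-fold lower number from compound 3 to compound 4 (0.30 log units; within the scatter), leaves those two compounds indistinguishable. No measurement shown here accounts for these differences.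

The compounds shown leave open whether the ring needs both of its methyl groups or whether other groups could serve in their place, such as an ethyl, a methoxy or a carboxylic acid. They also leave open whether a ring other than a phenyl on the carbonyl carbon, such as a pyridine, would keep the number as low.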